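The compounds below may be only part of what the source reports. "The series", "measured", "known", "first", "only" and "open" are said of these compounds alone.

In a functional assay on U-937 cells (Homo sapiens) for antiproliferative activity, read by MTT assay, with a stated time of 24 h (a higher number here means a weaker inhibitor, a lower number a stronger inhibitor), compound 1 (`CCCCc1oc2ccccc2c1C(=O)c1ccc(OCC(N)=O)cc1`) gives 42200 nM as its value, compound 2 (`CCCCc1oc2ccccc2c1C(=O)c1ccc(OCC(=O)N2CCCC2)cc1`) gives 32500 nM and compound 3 (`CCCCc1oc2ccccc2c1C(=O)c1ccc(OCC(=O)Nc2cccc(OC)c2)cc1`) gives 24200 nM on the same core. Compound 3 stands level with both others: its two steps (a 1.7-fold lower number from compound 1 to compound 3 (0.24 log units; within the scatter)) and (a 1.3-fold lower number from compound 2 to compound 3 (0.13 log units; within the scatter)) stay within the scatter, as does the remaining step (a 1.3-fold lower number from compound 1 to compound 2 (0.11 log units; within the scatter)).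

Compound 4 (`CCCCNC(=O)CCCOc1ccc(C(=O)c2c(CCCC)oc3ccccc23)cc1`) carries 2-(butylcarbamoyl)ethyl in place of (3-methoxyphenyl)carbamoyl on a saturated chain carbon bound to an oxygen on an aromatic ring. Within the data shown here, no measured step makes this exact change. The closest evidence is that the changes at the amide end, from compound 2 to compound 3 and from compound 1 to compound 3, moved the number by no more than the scatter. Nothing in these three compounds points to a direction, so no step beyond the scatter is expected in this assay here. The estimated step is small (a 1.2-fold higher number from compound 3 to compound 4 (0.09 log units; within the scatter)) and should not be read as a real change. For compound 4 the estimated value is 30000 nM (expected range 15000 nM to 60000 nM).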

Compound 4, half-maximal inhibitory concentration: 24600 nM
Compound 4: the middle estimate sits 1.2-fold (0.09 log units) above what was measured; measured number inside the range.
By their numbers in this assay, from the lowest: compounds 3, 4, 2 and 1 (each within the scatter of the next).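

In this assay, the open-chain 2-(butylcarbamoyl)ethyl takes the place of (3-methoxyphenyl)carbamoyl without a change beyond the scatter (a 1.0-fold higher number from compound 3 to compound 4 (0.01 log units; within the scatter)), so the six-membered aromatic ring of the departing group is not needed to reach this level. The two other comparisons at this position, with (pyrrolidin-1-yl)carbonyl (a 1.3-fold lower number from compound 2 to compound 4 (0.12 log units; within the scatter)) and with carbamoyl (a 1.7-fold lower number from compound 1 to compound 4 (0.23 log units; within the scatter)), also stay within the scatter, which leaves all four amides level with one another. No available evidence explains why these groups read alike.

On these data alone, whether any group on this saturated chain carbon can move the number beyond the scatter remains open. A carboxylic acid or an amine in place of the amide would test this, as would a longer chain on the amide nitrogen.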